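The source may report more compounds than this note shows. Statements on the series, on what has been measured and on what is new or still open speak of the compounds shown alone.

Measured compounds and their numbers in a functional assay, read by spectrophotometry, with a stated time of 30 min; a higher number here means that more compound is needed for the effect, a lower number that less compound is needed:

compound 1 `COc1cc(C2Oc3cc([C@H]4Oc5cc(O)cc(O)c5C(=O)[C@@H]4O)ccc3OC2COC(=O)c2cc(OC)c(OC)c(OC)c2)ccc1O`: 94800 nM
compound 2 `COc1cc(C2Oc3cc([C@H]4Oc5cc(O)cc(O)c5C(=O)[C@@H]4O)ccc3OC2COC(=O)c2ccccc2)ccc1O`: 105000 nM
compound 3 `COc1cc(C2Oc3cc([C@H]4Oc5cc(O)cc(O)c5C(=O)[C@@H]4O)ccc3OC2COC(=O)/C=C/c2ccc(C)cc2)ccc1O`: 136000 nM

The three share one core and differ only in the group on the carbonyl carbon of the ester. Compound 2 stands within the scatter of both neighbours: a 1.1-fold higher number from compound 1 to compound 2 (0.04 log units; within the scatter), and a 1.3-fold higher number from compound 2 to compound 3 (0.11 log units; within the scatter). Likewise a 1.4-fold higher number from compound 1 to compound 3 (0.16 log units; within the scatter). No step among the measured compounds reaches beyond the scatter, so the ester group has so far shown no effect on this assay that the scatter would not cover.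

Compound 4 `COc1cc(C2Oc3cc([C@H]4Oc5cc(O)cc(O)c5C(=O)[C@@H]4O)ccc3OC2COC(=O)/C=C/c2ccc(Br)cc2)ccc1O` is not yet measured. It differs from compound 2 in one place: 2-(4-bromophenyl)ethenyl in place of phenyl on a carbonyl carbon. For the measured compounds named here, the step that bears most directly on it is the one from compound 2 to compound 3, where a 2-(4-methylphenyl)ethenyl also replaced phenyl; that step stayed within the scatter. For compound 4 the step is therefore expected to be of the same kind, a 1.2-fold higher number from compound 2 to compound 4 (0.09 log units; within the scatter), no more than the scatter allows.

Compound 4 is expected to give 130000 nM in this assay, with a range from 65000 nM to 260000 nM.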

Compound 4, half-maximal effective concentration: 88900 nM
Compound 4: middle estimate off by 1.5-fold (0.17 log units), on the high side; the measured number falls inside the stated range.
By their numbers in this assay, from the lowest: compounds 4, 1, 2 and 3 (each within the scatter of the next).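

At the carbonyl carbon of the ester, 2-(4-bromophenyl)ethenyl joins the groups that leave the number in this assay within the scatter, with a 1.2-fold lower number from compound 2 to compound 4 (0.07 log units; within the scatter) and a 1.1-fold lower number from compound 1 to compound 4 (0.03 log units; within the scatter). The series also gains its first change made only on the aromatic ring of the ethenyl group: bromo in place of methyl on an aromatic carbon gives a 1.5-fold lower number from compound 3 to compound 4 (0.18 log units; within the scatter), so this exchange also shows no effect that the scatter would not cover. Nothing available explains why these numbers stay so close.

The compounds shown leave open whether an amine or a carboxylic acid on that aromatic ring, or a plain alkyl chain in place of the ring, would move the number beyond the scatter. On these data alone, whether an amide in place of the ester would do so also remains open.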